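Fluoro on the phenyl ring in two thiadiazole amide pairs

A few compounds are considered here, and "the series" means these few. Any claim that something is new, unique, unknown or untested is made for them only; others in the source may bear on it.

Measured so far:
compound 1, `O=C(Nc1nnc(-c2ccccc2)s1)c1cc(Br)ccc1O`, 1280 nM
compound 2, `O=C(Nc1nnc(-c2ccc(F)cc2)s1)c1cc(Br)ccc1O`, 1020 nM
compound 3, `O=C(Nc1nnc(-c2ccccc2)s1)c1ccccc1`, 5150 nM

The values come from a functional assay on B16-F10 cells (Mus musculus) for antiproliferative activity, read by MTT assay, with a stated time of 48 h; a lower number here means a stronger inhibitor, a higher number a weaker inhibitor. Compound 1 and compound 2 differ by fluoro in place of hydrogen on an aromatic carbon, and that change gave a 1.3-fold lower number from compound 1 to compound 2 (0.10 log units; within the scatter). Compound 3 has a different core; the difference between the two cores is not broken down here, and its value stands well apart from compound 1 and compound 2.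

Compound 4, `O=C(Nc1nnc(-c2ccc(F)cc2)s1)c1ccccc1`, has not yet been measured. It differs from compound 3 by fluoro in place of hydrogen on an aromatic carbon, the same change as that from compound 1 to compound 2. Because compound 1 to compound 2 gave a 1.3-fold lower number from compound 1 to compound 2 (0.10 log units; within the scatter), a step of similar size is expected from compound 3 to compound 4, a 1.3-fold lower number from compound 3 to compound 4 (0.10 log units; within the scatter). In this assay compound 4 is estimated at 4100 nM, expected between 2000 nM and 9000 nM.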

Compound 4, half-maximal inhibitory concentration: 4750 nM
Estimate against measurement, compound 4: 1.2-fold (0.06 log units) below; low and high end bracket the measured number.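

In this assay, phenyl to 4-fluorophenyl on the core of compound 3 gives a 1.1-fold lower number from compound 3 to compound 4 (0.04 log units; within the scatter), and this step matches the earlier one on the core of compound 1: the same change on two cores in this assay, a 1.3-fold lower number (0.10 log units; within the scatter) from compound 1 to compound 2 and a 1.1-fold lower number (0.04 log units; within the scatter) from compound 3 to compound 4, 1.2-fold (0.06 log units) apart, within the scatter of two such steps

Both steps lie within the scatter, so the change can be carried between these two cores with no measurable difference in outcome. This does not show that fluoro has a real effect on either core, nor that the same would hold on any core beyond these two.

Open, on these data alone, is whether a different group on the same aromatic carbon, such as an amine or a carboxylic acid, would give a step beyond the scatter. Also open, as far as these compounds go, is whether such a step would carry from one core to the other.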